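From 4-chlorophenyl to 2-hydroxyphenyl on the amide nitrogen

This account rests on a few compounds, and the source may have more. Where it says the series, first, only, none or still open, it means among the compounds named here.

Measured so far:
compound 1, `Cn1c(Cc2nn(C)c(=O)c3ccccc23)nnc1SCCCCCCCCCCC(=O)Nc1ccc(Cl)cc1Cl`: 3300 nM
compound 2, `Cn1c(Cc2nn(C)c(=O)c3ccccc23)nnc1SCCCCCCCC(=O)Nc1ccc(Cl)cc1`: 800 nM
compound 3, `CC(C)COc1ccc(NC(=O)CSc2nnc(Cc3nn(C)c(=O)c4ccccc34)n2C)cc1`: 30000 nM

All three compounds were tested in an assay on isolated protein (Mus musculus) for inhibition of IL15-IL15 receptor (Homo sapiens), read by resazurin assay, with stated times of 30 min and 2.5 days; a higher number here means a weaker inhibitor, a lower number a stronger inhibitor. Compound 2 gives the lowest number of the three. The nearest number belongs to compound 1, and that gap is beyond the usual scatter; compound 3 stands furthest away, also well beyond the scatter. Compound 2 is therefore the strongest inhibitor among the compounds measured here.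

The next compound, compound 4, is `Cn1c(Cc2nn(C)c(=O)c3ccccc23)nnc1SCCCCCCCC(=O)Nc1ccccc1O`. It keeps the shared core and the same chain as compound 2 and differs only at the far end: 2-hydroxyphenyl in place of 4-chlorophenyl on an amide-type nitrogen. Going by the values given here, no pair of measured compounds shows this particular change, so its effect can only be guessed. Because compound 2 gives 800 nM and the two chlorinated compounds 1 and 2 differ from each other beyond the scatter, the aryl end of the amide evidently matters, and a change that removes the chlorine altogether is expected to cost some potency. The expected step is a 3.1-fold higher number from compound 2 to compound 4 (0.49 log units; beyond the scatter), a weakening beyond the scatter. Compound 4 is estimated at 2500 nM, within a range of 700 nM to 9000 nM.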

Compound 4, half-maximal inhibitory concentration: 27000 nM
Estimate against measurement, compound 4: 11-fold (1.03 log units) below; the whole stated range lies below it.
By their numbers in this assay, from the lowest: compound 2; then compound 1; then compounds 4 and 3 (each within the scatter of the next).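

In this assay, replacing 4-chlorophenyl with 2-hydroxyphenyl on the amide-type nitrogen gives a 34-fold higher number from compound 2 to compound 4 (1.53 log units; beyond the scatter) in a single large step, beyond the scatter. The shared core and the chain stay the same and both end groups have the same count of heavy atoms, so this pair isolates the aryl end and shows that potency depends strongly on what that ring carries. Nothing available explains the size of this loss.

The step removes a chlorine and adds a hydroxyl at once, so the compounds shown leave open which of the two accounts for the loss; an unsubstituted phenyl on the same nitrogen would separate them. They also leave open how 2-chlorophenyl or 4-hydroxyphenyl would behave, and so whether the substituent's place on the ring matters.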